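The source may hold more compounds than are shown below. What is called first, only, known or untested is meant among the compounds shown, and "the series" means these compounds.

Compound 1, `O=C(OCc1ccccc1)c1cccc(=O)[nH]1`: 69000 nM in an assay on isolated protein for inhibition of matrix metalloproteinase-9 (Homo sapiens); on this read-out higher numbers stand for weaker inhibition and lower numbers for stronger inhibition.
Compound 2, `O=C(OCc1ccccc1Cl)c1cccc(=O)[nH]1`: 81000 nM in this assay.
Compound 3, `O=C(OCc1cccc(C(F)(F)F)c1)c1cccc(=O)[nH]1`: not yet measured in this assay.

For the measured compounds named here, compound 1 sits at one end of the two numbers measured so far in this assay, with compound 2 its only neighbour, and the step of a 1.2-fold higher number from compound 1 to compound 2 (0.07 log units; within the scatter) is within the scatter, so the two compounds cannot be separated. Compound 3 differs from compound 1 by trifluoromethyl in place of hydrogen on an aromatic carbon. Going by the values given here, the single measured step that bears on this change is a 1.2-fold higher number from compound 1 to compound 2 (0.07 log units; within the scatter), which also puts a substituent on the benzylic ring of the ester and leaves the number where it was. With that one precedent, compound 3 is expected to give a step of a 1.1-fold higher number from compound 1 to compound 3 (0.04 log units; within the scatter), that is, nothing beyond the scatter. The estimate for compound 3 in this assay is therefore 75000 nM, with a range from 30000 nM to 180000 nM.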

Compound 3, half-maximal inhibitory concentration: > 150 nM
Compound 3 ended at the assay's limit; the forecaster's own chance of this, stated with the estimate: 25%; the middle value is on the limit's open side.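

Compound 3 gave a limit of the assay and not a number, so the step from compound 1 to compound 3 cannot be read: the limit of > 150 nM in this assay, at which 1 of the 3 values shown sits.

The compounds shown leave open whether trifluoromethyl in place of hydrogen on an aromatic carbon moves the number in this assay at all, and in which direction.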